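The compounds below may be only part of what the source reports. "The series", "measured", "known", "first", "only" and "open" are said of these compounds alone.

Measured compounds:
- compound 1 `O=C(Nc1cccc([N+](=O)[O-])c1)C1CCCN(C(=O)c2cc(C(F)(F)F)cc(C(F)(F)F)c2)C1`, 9%
- compound 2 `O=C(Nc1cccc(Oc2ccccc2)c1)C1CCCN(C(=O)c2cc(C(F)(F)F)cc(C(F)(F)F)c2)C1`, 1%
- compound 3 `O=C(c1ccccc1)c1cccc(NC(=O)C2CCCN(C(=O)c3cc(C(F)(F)F)cc(C(F)(F)F)c3)C2)c1`, 0%

In an ADME assay on PC-3 cells (Homo sapiens) for cytotoxicity, read by WST assay, tested at 100 uM (on this read-out higher numbers stand for more inhibition at the one concentration tested (going by the name of the read-out) and lower numbers for less inhibition), compound 1 gives 9%, nominally the top number of the three, but the steps of a number 8 percentage points lower from compound 1 to compound 2 (within the scatter) and a number 9 percentage points lower from compound 1 to compound 3 (within the scatter) are both within the scatter, so the three measured compounds are not separated on this read-out. The step of a number 1 percentage points lower from compound 2 to compound 3 (within the scatter) is likewise within the scatter. All three compounds share the same core and differ only in the group on the aromatic ring attached to the amide-type nitrogen.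

Compound 4 `O=C(Nc1ccc(Cl)cc1)C1CCCN(C(=O)c2cc(C(F)(F)F)cc(C(F)(F)F)c2)C1` has not yet been measured. It differs from compound 1 as follows: 4-chlorophenyl in place of 3-nitrophenyl on an amide-type nitrogen. Among the measured compounds shown here, no measured step replaces 3-nitrophenyl with 4-chlorophenyl, so the nearest evidence is the two steps leaving compound 1, from compound 1 to compound 2 and from compound 1 to compound 3, where swapping the nitro for either phenoxy or benzoyl moved the number only within the scatter, and the step from compound 2 to compound 3 as a third change at the same place with the same outcome.

On that basis the step of a number 4 percentage points lower from compound 1 to compound 4 (within the scatter) is expected to stay within the scatter, with no direction claimed. The estimate for compound 4 in this assay is 5%, range 0% to 20%.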

Compound 4, a percentage reported as inhibition, at one concentration (the size of the read-out at that concentration, not a potency): 14%
For compound 4 the middle estimate is 9 percentage points below the measured one; low and high end bracket the measured number.
By their numbers in this assay, from the lowest: compounds 3, 2, 1 and 4 (each within the scatter of the next, the first and the last beyond it).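

Among the compounds shown here, replacing 3-nitrophenyl with 4-chlorophenyl on an amide-type nitrogen gives a number 5 percentage points higher from compound 1 to compound 4 (within the scatter), so in this assay exchanging the whole aryl group, and not only a substituent named in the earlier steps, still does not separate this pair. The four compounds do show their first separation: compound 3 gives 0% and compound 4 gives 14%, a gap beyond the scatter, although each neighbouring pair in the order remains within it, and all of these numbers describe one concentration rather than a potency. Nothing measured here offers an explanation for this result.

The compounds shown leave open whether the number for compound 4 goes with the chlorine or with its place on the aryl ring, a question that a 3-chlorophenyl or 4-nitrophenyl group on the same amide-type nitrogen would address. Also open, from the compounds shown here alone, is how an aryl ring carrying an amine or a carboxylic acid would read, and whether any change to the shared core outside this aryl group would move the number beyond the scatter.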